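The source may hold more compounds than are shown below. What is called first, only, known or untested is meant among the compounds shown, and "the series" means these compounds.

Measured compounds:
compound 1, `CON(Cc1cccs1)C(=O)COc1ccc(C)cc1`, an assay on HEK293 cells for agonist activity at transient receptor potential cation channel subfamily M member 8 (Homo sapiens), read by fluorescence and calcium flux, with a stated time of 15 min; a lower number here means that less compound is needed, a higher number that more compound is needed for the effect: 10 nM
compound 2, `Cc1ccc(OCC(=O)N(Cc2cccs2)c2ccncc2)cc1`, this assay: 52 nM

For the measured compounds named here, compound 2 gives the highest of the two numbers so far. Going by the values given here, its only neighbour is compound 1, and the change between them sits on the amide-type nitrogen: a 5.2-fold higher number from compound 1 to compound 2 (0.72 log units; beyond the scatter). So the one measured step in the series is at exactly the position now altered, and it shows that moving from methoxy to the larger pyridin-4-yl went with a modest rise in the number.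

Compound 3, `C=CCN(Cc1cccs1)C(=O)COc1ccc(C)cc1`, differs from compound 2 as follows: allyl in place of pyridin-4-yl on an amide-type nitrogen. Among the compounds with values here, the only step that bears on this change is the step from compound 1 to compound 2, which was modest and beyond the scatter. Compound 3 reverts to a small group at the same nitrogen, so a step back toward the number of compound 1 is expected, though allyl is not methoxy and the size of the return is uncertain. The expected step is a 2.9-fold lower number from compound 2 to compound 3 (0.46 log units; beyond the scatter). For compound 3 in this assay the estimate is 18 nM, within a range of 6 nM to 60 nM.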

Compound 3, half-maximal effective concentration: 20 nM
For compound 3 the middle estimate is 1.1-fold (0.05 log units) below the measured one; the range from low to high includes it.
By their numbers in this assay, from the lowest: compounds 1 and 3 (each within the scatter of the next); then compound 2.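

At the amide-type nitrogen, allyl in place of pyridin-4-yl gives a 2.6-fold lower number from compound 2 to compound 3 (0.41 log units; beyond the scatter) in this assay so a small group without a ring undoes much of the rise seen with pyridin-4-yl, which the earlier pair could not show. Allyl in place of methoxy gives a 2.0-fold higher number from compound 1 to compound 3 (0.30 log units; within the scatter) so these two groups cannot be told apart at this position, even though they share little beyond their small size, and among the three groups at this nitrogen only pyridin-4-yl stands apart from the others; with a single ring-bearing compound, this is an observation about these three compounds and not a trend. Nothing available here accounts for the difference between pyridin-4-yl and the two smaller groups.

On these data alone, whether the higher number goes with the presence of a ring in general or with the ring nitrogen of pyridin-4-yl stays open, and a phenyl group at the same nitrogen would separate the two cases. As far as these compounds go, how much larger a group without a ring can be here also stays open, and a longer saturated chain such as n-butyl, or a chain ending in an amine, would test that.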